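Amide Substituent Swap on a Shared Core

A few compounds are considered here, and "the series" means these few. Any claim that something is new, unique, unknown or untested is made for them only; others in the source may bear on it.

Measured so far:
Compound 1 `Cn1nnc(-c2sc(-c3cccc(F)c3)nc2O)n1`: 214 nM
Compound 2 `CON(C)C(=O)c1sc(-c2cccc(F)c2)nc1O`: 96 nM

Among the compounds with values here, in an assay on HEK293 cells for inhibition of transient receptor potential cation channel subfamily M member 8 (Homo sapiens), read by FLIPR, with stated times of 5 min and 3 min (a higher number here means a weaker inhibitor, a lower number a stronger inhibitor), compound 2 stands at the lowest of the two numbers, and the single measured step is a 2.2-fold lower number from compound 1 to compound 2 (0.35 log units; beyond the scatter). Compound 3 `O=C(c1sc(-c2cccc(F)c2)nc1O)N1CCOCC1` differs from compound 2 in one place: morpholin-4-yl in place of methoxy(methyl)amino on a carbonyl carbon. That earlier step replaced the whole group on the aromatic carbon, whereas this change keeps the carbonyl and exchanges only the amine part, so it bears on the new step only loosely. The expectation is therefore a 1.3-fold higher number from compound 2 to compound 3 (0.10 log units; within the scatter), nothing beyond the scatter. Compound 3 is estimated at 120 nM, between 50 nM and 300 nM.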

Compound 3, half-maximal inhibitory concentration: 12200 nM
Beside the measured number, compound 3's estimate is 100-fold (2.01 log units) below it, and the stated range ends below it.
By their numbers in this assay, from the lowest: compound 2; then compound 1; then compound 3.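

In this assay, keeping the carbonyl and exchanging only the amine part, morpholin-4-yl in place of methoxy(methyl)amino, gives a 130-fold higher number from compound 2 to compound 3 (2.10 log units; beyond the scatter). This far exceeds the modest earlier change on the aromatic carbon, a 2.2-fold lower number from compound 1 to compound 2 (0.35 log units; beyond the scatter), and shows that the amine part on this carbonyl carbon alone can largely set the number. Nothing available accounts for the size of this step. The compounds shown leave open how dimethylamino or piperidin-1-yl would read on the same carbonyl carbon. They therefore cannot separate the ring of morpholin-4-yl from its oxygen.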